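The source may hold more compounds than are shown below. What is called first, only, known or untested is meant among the compounds shown, and "the series" means these compounds.

Measured compounds and their values:
- compound 1, `COc1ccccc1/C=c1/[nH]c(=O)/c(=C\c2cccc(Cl)c2Cl)[nH]c1=O`: "not active" (no number reported)
- compound 2, `C=CCn1c(=O)/c(=C\c2cc(Br)ccc2F)[nH]c(=O)/c1=C\c1ccccc1OC`: 4700 nM
- compound 3, `C=CCn1c(=O)/c(=C\c2ccc(Cl)c(Cl)c2)[nH]c(=O)/c1=C\c1ccccc1`: "not active" (no number reported)

Among the measured compounds shown here, in a functional assay on U-937 cells (Homo sapiens) for cytotoxicity, read by CCK-8 assay, with a stated time of 72 h (a higher number here means a weaker inhibitor, a lower number a stronger inhibitor), compound 2 gives 4700 nM and is the only compound of the three with a number; compound 1 and compound 3 are each recorded without a figure, so compound 2 stands as the single reference point for any estimate.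

Compound 4, `C=CCn1c(=O)/c(=C\c2cc(F)ccc2C)[nH]c(=O)/c1=C\c1ccccc1OC`, has not yet been measured in this assay. It differs from compound 2 in one place: 5-fluoro-2-methylphenyl in place of 5-bromo-2-fluorophenyl on a double-bonded chain carbon bound to an aromatic carbon. The shared core, the allyl on the ring nitrogen and the 2-methoxyphenyl on the other double-bonded chain carbon are kept. For the measured compounds named here, no pair of measured compounds shows a step of this kind, so there is nothing to size it from; compound 1 and compound 3 carry different halogen patterns but give no numbers to compare.

With only a change among the ring substituents and no guide from the numbers, the step from compound 2 to compound 4 is expected to be a 1.3-fold higher number from compound 2 to compound 4 (0.11 log units; within the scatter), small and not clearly beyond the scatter, if anything toward a weaker inhibitor. Compound 4 is accordingly estimated at 6000 nM, with a range from 2500 nM to 20000 nM.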

Compound 4, half-maximal inhibitory concentration: 1000 nM
Compound 4: the middle estimate sits 6.0-fold (0.78 log units) above what was measured; the whole stated range lies above it.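

In this assay, the substituted phenyl on the double-bonded chain carbon bound to an aromatic carbon now has a measured effect: 5-fluoro-2-methylphenyl in place of 5-bromo-2-fluorophenyl gives a 4.7-fold lower number from compound 2 to compound 4 (0.67 log units; beyond the scatter). The earlier compounds shown here offered a single number and therefore no step, whereas this pair shows that the read-out responds to this position beyond the scatter while the shared core, the allyl on the ring nitrogen and the 2-methoxyphenyl stay fixed. The change also leaves the counts of heavy atoms, hydrogen-bond donors and hydrogen-bond acceptors in the group unaltered, and nothing available accounts for the shift in the number.

This one step replaces the bromine and the ring fluorine with a methyl and a fluorine together, so it cannot assign the shift to any single substituent, and steps involving compound 1 or compound 3 cannot be read without numbers. Going by these compounds, it also remains open whether an amine or a carboxylic acid on this phenyl would keep, improve or lose the value seen for compound 4.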